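Replacing piperidin-1-yl with 1H-imidazol-1-yl in compound 2

The source may hold more compounds than are shown below. What is called first, only, known or untested is meant among the compounds shown, and "the series" means these compounds.

In a functional assay on A549 cells (Homo sapiens) for antiproliferative activity, read by MTT assay, with a stated time of 48 h (a higher number here means a weaker inhibitor, a lower number a stronger inhibitor), compound 2 `Cn1cc(C2=C(c3nn(CCCN4CCCCC4)c4ncccc34)C(=O)N(c3ccccc3)C2=O)c2ccccc21` gives 20600 nM, the higher of the two actual numbers available. Compound 3 `Cn1cc(C2=C(c3nn(CCCN4CCCCC4)c4ncccc34)C(=O)N(c3cccc4ccccc34)C2=O)c2ccccc21` gives 2820 nM. Compound 1 `Cn1cc(C2=C(c3nn(CCCn4cncn4)c4ncccc34)C(=O)N(c3ccccc3)C2=O)c2ccccc21` is reported only as a limit, > 100000 nM.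

Compound 4 `Cn1cc(C2=C(c3nn(CCCn4ccnc4)c4ncccc34)C(=O)N(c3ccccc3)C2=O)c2ccccc21` differs from compound 2 in one place: 1H-imidazol-1-yl in place of piperidin-1-yl on a saturated chain carbon, three bonds along the chain from an aromatic nitrogen. Here 1H-imidazol-1-yl stands in place of piperidin-1-yl on a saturated chain carbon, three bonds along the chain from an aromatic nitrogen.

The most relevant evidence comes from the same place, where piperidin-1-yl replaces 1H-1,2,4-triazol-1-yl: an at least 4.8-fold lower number from compound 1 to compound 2 (0.68 log units; beyond the scatter). The incoming 1H-imidazol-1-yl is also a five-membered aromatic ring, so this change may partly run that step in reverse. The other measured step, a 7.3-fold lower number from compound 2 to compound 3 (0.86 log units; beyond the scatter), swaps phenyl for naphthalen-1-yl on an amide-type nitrogen in a ring, elsewhere in the molecule, and bears little on this question.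

The expected change is a 2.2-fold higher number from compound 2 to compound 4 (0.34 log units; beyond the scatter), towards a higher number and so a weaker inhibitor. For compound 4 the estimated value is 45000 nM, with an expected range of 15000 nM to 100000 nM.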

Compound 4, half-maximal inhibitory concentration: 1560 nM
For compound 4 the middle estimate is 29-fold (1.46 log units) above the measured one; the measured number lies below the stated range.
By their numbers in this assay, from the lowest: compounds 4 and 3 (each within the scatter of the next); then compound 2. At a limit, above all of these: compound 1.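

Among these compounds, at this position the identity of the ring matters more than the earlier compounds could show: in this assay, putting the aromatic 1H-imidazol-1-yl in place of the saturated piperidin-1-yl gives a 13-fold lower number from compound 2 to compound 4 (1.12 log units; beyond the scatter), so a five-membered aromatic ring here does not by itself weaken the compound. The two five-membered aromatic rings also differ sharply from each other, with an at least 64-fold lower number from compound 1 to compound 4 (1.80 log units; beyond the scatter). The true size of that step is unknown, as it rests on a limit for compound 1: the limit of > 100000 nM in this assay, at which 1 of the 4 values shown sits.

From the compounds shown here alone, it remains open whether the result holds for 1H-imidazol-1-yl on a longer chain, such as butyl, or for 1H-pyrazol-1-yl at the same place. Also open, going by these compounds, is whether naphthalen-1-yl on the amide-type nitrogen would add to the effect of 1H-imidazol-1-yl in one molecule.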